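The source may report more compounds than this note shows. Statements on the series, on what has been measured and on what is new or still open speak of the compounds shown alone.

Measured in a functional assay on NCI-H460 cells (Homo sapiens); on this read-out higher numbers stand for weaker inhibition of growth and lower numbers for stronger inhibition of growth:
- compound 1 `Oc1cc(-c2ccc(Cl)cc2)nc2ncccc12` gives 38000 nM
- compound 2 `COc1cccc(-c2cc(O)c3cc(C)cnc3n2)c1` gives 43.7 nM
- compound 3 `COc1ccccc1-c1cc(O)c2cccnc2n1` gives 38900 nM

Compound 2 has the lowest number of the three and stands well beyond the scatter from both others. The values of compound 1 and compound 3 lie within the scatter of each other.

The next compound is compound 4 `COc1cccc(-c2cc(O)c3cccnc3n2)c1`, which has hydrogen in place of methyl on an aromatic carbon, two atoms from the ring nitrogen: hydrogen in place of methyl on an aromatic carbon. Among the measured compounds shown here, no measured pair isolates this change. Compound 1 and compound 3 also lack the methyl, but each differs from compound 4 elsewhere, so neither settles its size. The change is small, and compound 4 keeps the rest of compound 2, so a moderate loss is expected rather than a fall to the level of the other two. The expected step, towards weaker inhibition of growth in this assay, is a 6.9-fold higher number from compound 2 to compound 4 (0.84 log units; beyond the scatter). The estimated value for compound 4 is 300 nM, with an expected range of 40 nM to 5000 nM.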

Compound 4, concentration for 50% growth inhibition: 91.2 nM
Compound 4: middle estimate off by 3.3-fold (0.52 log units), on the high side; low and high end bracket the measured number.
By their numbers in this assay, from the lowest: compound 2; then compound 4; then compounds 1 and 3 (each within the scatter of the next).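

Among the compounds shown here, this is the first reading that isolates the methyl on this aromatic carbon: in this assay, hydrogen in its place gives a 2.1-fold higher number from compound 2 to compound 4 (0.32 log units; beyond the scatter), a modest step that is still beyond the scatter. The position therefore accepts the loss of the methyl with compound 4 still at 91.2 nM, so the methyl contributes to the low number of compound 2 but is not needed for a number of this order. Nothing at hand explains the size of this step.

What an ethyl group, a chlorine or an amine would give at this carbon remains open, since only methyl and hydrogen are shown there. Also open, on these data alone, is whether adding the methyl would shift the much higher numbers of compound 1 and compound 3 by a similar step.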